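The source may hold more compounds than are shown below. What is called first, only, known or untested is meant among the compounds shown, and "the series" means these compounds.

Values in a functional assay on HepG2 cells (Homo sapiens) for cytotoxicity, read by MTT assay, with a stated time of 72 h; on this read-out higher numbers stand for weaker inhibition and lower numbers for stronger inhibition:
Compound 1 `Cc1cc(=O)n(-c2cccc(F)c2)nc1C(=O)Nc1ccc(Oc2ncnc3[nH]ccc23)cc1`: 3180 nM
Compound 2 `Cc1cc(=O)n(-c2ccc(Br)cc2F)nc1C(=O)Nc1ccc(Oc2ncnc3c2ccn3C)cc1`: 33600 nM
Compound 3 `Cc1cc(=O)n(-c2cccc(F)c2)nc1C(=O)Nc1ccc(Oc2ncnc3c2ccn3C)cc1`: > 60000 nM

Compound 3 has only a limit and no number: > 60000 nM. That is the limit of > 60000 nM in this assay, at which 1 of the 3 values shown sits.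

Compound 4 `Cc1cc(=O)n(-c2ccccc2C(F)(F)F)nc1C(=O)Nc1ccc(Oc2ncnc3c2ccn3C)cc1` has 2-(trifluoromethyl)phenyl in place of 3-fluorophenyl on an aromatic nitrogen. Going by the values given here, the one measured step that changes the group at this place is an at least 1.7-fold higher number from compound 2 to compound 3 (0.25 log units; that floor lies within the scatter), and its floor lies within the scatter. The large step of an at least 18-fold higher number from compound 1 to compound 3 (1.27 log units; beyond the scatter) is a different change, methyl in place of hydrogen on an aromatic nitrogen, and compound 4 keeps that methyl. Both methylated compounds therefore bear on the expectation, and so does compound 2 at 33600 nM. No step beyond the scatter is expected in this assay, and a reading that again gives only a limit is quite possible. The expected change is an at least 1.2-fold lower number from compound 3 to compound 4 (0.07 log units; that floor lies within the scatter). Compound 4 is estimated at 50000 nM, with an expected range of 20000 nM to 120000 nM.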

Compound 4, half-maximal inhibitory concentration: 27200 nM
The estimate for compound 4 lay 1.8-fold (0.26 log units) above the measured number; measured number inside the range.
By their numbers in this assay, from the lowest: compound 1; then compounds 4 and 2 (each within the scatter of the next). At a limit, above all of these: compound 3.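

In this assay, the group on the aromatic nitrogen now gives a change beyond the scatter with the methyl kept: the exchange of 3-fluorophenyl for 2-(trifluoromethyl)phenyl gives an at least 2.2-fold lower number from compound 3 to compound 4 (0.34 log units; beyond the scatter), whereas the earlier step at this place had a floor within the scatter. On these data alone, compound 3 has only a limit, so the true size of this step stays unknown: the limit of > 60000 nM in this assay, at which 1 of the 4 values shown sits. The two larger groups are not told apart, since a 1.2-fold lower number from compound 2 to compound 4 (0.09 log units; within the scatter) separates 2-(trifluoromethyl)phenyl from 4-bromo-2-fluorophenyl by no more than the scatter.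

As far as these compounds go, it stays open whether hydrogen in place of the methyl on the aromatic nitrogen would, with 2-(trifluoromethyl)phenyl, repeat the size of an at least 18-fold higher number from compound 1 to compound 3 (1.27 log units; beyond the scatter). From the compounds shown here alone, how a phenyl carrying an amine or a carboxylic acid would read at this place also stays open.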